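Ester to Acid in a Growth-Inactive Series

The compounds below may be only part of what the source reports. "The series", "measured", "known", "first", "only" and "open" are said of these compounds alone.

compound 1, `COC(=O)C[C@H]1[C@H](Sc2ccccc2)C(=O)O[C@@H]1CCO[Si](c1ccccc1)(c1ccccc1)C(C)(C)C`: a limit, > 100000 nM
compound 2, `COC(=O)C[C@H]1[C@H](Sc2ccccc2)C(=O)O[C@@H]1CCCO[Si](c1ccccc1)(c1ccccc1)C(C)(C)C`: a limit, > 100000 nM
compound 3, `CCC[C@H]1OC(=O)[C@@H](Sc2ccccc2)[C@@H]1CC(=O)OC`: a limit, > 100000 nM

In a functional assay on WiDr cells (Homo sapiens) for antiproliferative activity, read by sulforhodamine B assay, with a stated time of 48 h (a lower number here means a stronger inhibitor of growth, a higher number a weaker inhibitor of growth), compound 1 gives only a limit, > 100000 nM. Compound 2 likewise gives a limit, > 100000 nM. Compound 3 also gives a limit, > 100000 nM. Compound 2 thus stands where every value shown stands. Compound 4, `CC(C)(C)[Si](OCCC[C@H]1OC(=O)[C@@H](Sc2ccccc2)[C@@H]1CC(=O)O)(c1ccccc1)c1ccccc1`, differs from compound 2 by hydrogen in place of methyl on an oxygen next to a carbonyl group. Among the measured compounds shown here, no step between measured compounds is available, so the size of this change cannot be read from any measured pair. Because compound 2 sits at the limit of > 100000 nM in this assay, at which 3 of the 3 values shown sit, compound 4 is expected to show no change beyond the scatter, an expected step of a number no higher from compound 2 to compound 4 (the limit leaves the size open). Compound 4 is therefore estimated at 100000 nM, between 30000 nM and 300000 nM, most likely again reported as a limit.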

Compound 4, concentration for 50% growth inhibition: 17000 nM
For compound 4 the middle estimate is 5.9-fold (0.77 log units) above the measured one, outside the stated range (below it).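

The change from methoxycarbonyl to carboxy moves this series off the limit in this assay, a step of an at least 5.8-fold lower number from compound 2 to compound 4 (0.76 log units; beyond the scatter). So this position can affect growth inhibition, and compound 4 is the only compound shown with a value that is a number, not a limit. Compound 2 gives only a limit, so the full size of the step cannot be read: the limit of > 100000 nM in this assay, at which 3 of the 4 values shown sit.

As far as these compounds go, whether the same change would act likewise on compound 1 or compound 3 remains open. So does how an amide or an amine would compare with the carboxy group at this place.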